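From Compound 2 to Compound 3: Losing the Carbonyl

This account rests on a few compounds, and the source may have more. Where it says the series, first, only, none or still open, it means among the compounds named here.

For the measured compounds named here, in a functional assay on U-251 cells (Homo sapiens) for inhibition, read by sulforhodamine B assay, with a stated time of 48 h (a higher number here means a weaker inhibitor of growth, a lower number a stronger inhibitor of growth), compound 2 (`CCCCCCCCCCCC[C@@H](O)[C@H]1CC[C@H]([C@H](O)CCCCCCCCCCN(C)C(=O)c2ccnn2C)O1`) gives 10000 nM, the lower of the two numbers so far, while compound 1 (`CCCCCCCCCCCC[C@@H](O)[C@H]1CC[C@H]([C@H](O)CCCCCCCCCCNC(=O)c2ccnn2C)O1`) gives 100000 nM. Compound 3 (`CCCCCCCCCCCC[C@@H](O)[C@H]1CC[C@H]([C@H](O)CCCCCCCCCCNCc2ccnn2C)O1`) alters the far end of the chain: ((1-methyl-1H-pyrazol-5-yl)methyl)amino in place of methyl((1-methyl-1H-pyrazol-5-yl)carbonyl)amino on a saturated chain carbon, ten or more bonds along the chain from an oxygen on a saturated carbon and a saturated ring carbon. Going by the values given here, the only measured step, a 10-fold lower number from compound 1 to compound 2 (1.00 log units; beyond the scatter), came with methyl in place of hydrogen on an amide-type nitrogen. Among the compounds with values here, compound 3 again has that hydrogen but also lacks the carbonyl, which no measured step covers, so a modest move to a higher number is expected, smaller than a 10-fold lower number from compound 1 to compound 2 (1.00 log units; beyond the scatter). The estimated step is a 2.5-fold higher number from compound 2 to compound 3 (0.40 log units; beyond the scatter). For compound 3, the expected value is 25000 nM, within an estimated range of 5000 nM to 100000 nM.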

Compound 3, concentration for 50% growth inhibition: 1510 nM
Beside the measured number, compound 3's estimate is 17-fold (1.22 log units) above it; the whole stated range lies above it.
By their numbers in this assay, from the lowest: compound 3; then compound 2; then compound 1.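

Removing the carbonyl at the far end of the chain gives a 6.6-fold lower number from compound 2 to compound 3 (0.82 log units; beyond the scatter) in this assay and, with the amide hydrogen kept, a 66-fold lower number from compound 1 to compound 3 (1.82 log units; beyond the scatter). At this end of the chain, the amine of compound 3 therefore gives a lower number than either amide, so the amide carbonyl is not needed for growth inhibition here. No measured evidence explains this gain.

The compounds shown leave open what a methyl on this amine nitrogen would do. They also leave open whether a phenyl or pyridine group could replace the 1-methyl-1H-pyrazol-5-yl group.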